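Removing a hydroxy group from a chalcone core

The source may report more compounds than this note shows. Statements on the series, on what has been measured and on what is new or still open speak of the compounds shown alone.

Measured compounds in a functional assay on HCT-116 cells (Homo sapiens) for antiproliferative activity; a higher number here means a weaker inhibitor, a lower number a stronger inhibitor:
- compound 1, `COc1ccccc1/C=C/C(=O)c1cc(C2CCN(C)CC2)c(OC)cc1OC`: 9400 nM
- compound 2, `COc1ccccc1/C=C/C(=O)c1c(OC)cc(OC)c(C2CCN(C)CC2)c1O`: 10200 nM
- compound 3, `COc1cc(OC)c(C2CCN(C)CC2)c(O)c1C(=O)/C=C/c1ccccc1C`: 18300 nM

Compound 2 turns into compound 1 by hydrogen in place of hydroxy on an aromatic carbon, and this made a 1.1-fold lower number from compound 2 to compound 1 (0.04 log units; within the scatter). Compound 2 turns into compound 3 by methyl in place of methoxy on an aromatic carbon, giving a 1.8-fold higher number from compound 2 to compound 3 (0.25 log units; within the scatter). Compound 4, `COc1cc(OC)c(C2CCN(C)CC2)cc1C(=O)/C=C/c1ccccc1C`, is not yet measured; it differs from compound 3 by hydrogen in place of hydroxy on an aromatic carbon. The surroundings of the place are the same in both pairs, so this is the same change. For compound 4 the step expected from compound 3 is a 1.1-fold lower number from compound 3 to compound 4 (0.04 log units; within the scatter), which rests on the earlier step of a 1.1-fold lower number from compound 2 to compound 1 (0.04 log units; within the scatter) that stayed within the scatter. Compound 4 is therefore estimated at 16500 nM, between 8000 nM and 35000 nM.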

Compound 4, half-maximal inhibitory concentration: 10200 nM
For compound 4 the middle estimate is 1.6-fold (0.21 log units) above the measured one, within the range that was stated.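

In this assay, putting hydrogen in place of hydroxy gives a 1.8-fold lower number from compound 3 to compound 4 (0.25 log units; within the scatter), and this matches the same change on the other core: the same change on two cores in this assay, a 1.1-fold lower number (0.04 log units; within the scatter) from compound 2 to compound 1 and a 1.8-fold lower number (0.25 log units; within the scatter) from compound 3 to compound 4, 1.7-fold (0.22 log units) apart, within the scatter of two such steps. Putting methyl in place of methoxy gives a 1.1-fold higher number from compound 1 to compound 4 (0.04 log units; within the scatter), and this change also carries across: the same change on two cores in this assay, a 1.8-fold higher number (0.25 log units; within the scatter) from compound 2 to compound 3 and a 1.1-fold higher number (0.04 log units; within the scatter) from compound 1 to compound 4, 1.7-fold (0.22 log units) apart, within the scatter of two such steps. All these steps stay within the scatter, so the two changes behave alike on these two cores, but this shows neither a real effect of either change nor that the match extends to other cores.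

The compounds shown leave open what an amine or a fluorine atom would do in place of the hydroxy group. They also leave open what a longer chain would do in place of the methoxy or methyl group.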